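The source may hold more compounds than are shown below. What is called first, only, known or untested is meant among the compounds shown, and "the series" means these compounds.

Measured so far:
- compound 1, `CC(C)c1ccn2ncnc(N[C@H]3CC[C@H](N(C)C)CC3)c12`: 1.3
- compound 2, `CN(C)[C@H]1CC[C@H](Nc2ncnc3cscc23)CC1`: 0.3
- compound 3, `Cn1ccc2ncnc(N[C@H]3CC[C@H](N(C)C)CC3)c21`: -0.8

In a physicochemical assay for lipophilicity, using the shake flask method, at pH 7.4 (a lower number here means a more polar compound, a higher number a more lipophilic compound), compound 3 gives -0.8, the lowest of the three numbers. Compound 2 is the nearest to it, with its value of 0.3 lying beyond the scatter above compound 3; compound 1 is the furthest, its value of 1.3 also beyond the scatter above compound 3. The three compounds share the same saturated ring with the dimethylamino group and differ only in the fused core, so these gaps reflect the core alone.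

Compound 4, `CN(C)[C@H]1CC[C@H](Nc2ncnc3cc[nH]c23)CC1`, has not been measured in this assay. It differs from compound 3 by hydrogen in place of methyl on an aromatic nitrogen, that is, on the aromatic nitrogen of the five-membered aromatic ring with 1 nitrogen within the fused system of two rings. Within the data shown here, no measured pair shows this exact change, so the size of the step cannot be read from a neighbour. The step from compound 3 to compound 4 is expected to be small and downward, a number 0.30 log units lower from compound 3 to compound 4 (within the scatter), at roughly the edge of the scatter. For compound 4 the expected value in this assay is -1.1, with a range from -1.6 to -0.6.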

Compound 4, distribution coefficient: -0.3
For compound 4 the middle estimate is 0.80 log units below the measured one, and the stated range ends below it.
By their numbers in this assay, from the lowest: compound 3; then compound 4; then compound 2; then compound 1.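

In this assay the change from methyl to hydrogen on the aromatic nitrogen gives a number 0.50 log units higher from compound 3 to compound 4 (beyond the scatter) and so sets the direction of this change at this position: the compound carrying hydrogen has the higher number. Among these compounds, this is the first pair that differs in one place, whereas compound 1 and compound 2 differ from compound 3 in the core and could not show what this nitrogen substituent alone does. No measurement shown bears on why the step runs in this direction.

A single pair leaves open whether the same step would appear on another core. It also leaves open where an ethyl group, a longer chain or a chain ending in an amine on this aromatic nitrogen would fall relative to hydrogen and methyl.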